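Working notes: losing one fluoro group on two cores

A few compounds are considered here, and "the series" means these few. Any claim that something is new, unique, unknown or untested is made for them only; others in the source may bear on it.

Measured so far:
compound 1 `COc1ccc(NS(=O)(=O)c2cc(F)c(F)c(F)c2F)cc1` — 370 nM
compound 2 `COc1ccc(NS(=O)(=O)c2c(F)cc(F)c(F)c2F)cc1` — 5800 nM
compound 3 `COc1ccc(NS(=O)(=O)c2cc(F)c(F)c(F)c2)cc1` — 3900 nM

All three values come from a functional assay on HeLa cells (Homo sapiens) for cytotoxicity; a lower number here means a stronger inhibitor of growth, a higher number a weaker inhibitor of growth. Compound 1 and compound 2 have the same atoms joined differently; the difference between the two cores is not broken down here. From compound 1 to compound 3 the change is hydrogen in place of fluoro on an aromatic carbon, and it gave an 11-fold higher number from compound 1 to compound 3 (1.02 log units; beyond the scatter). Compound 4 `COc1ccc(NS(=O)(=O)c2c(F)cc(F)cc2F)cc1` is not yet measured; it arises from compound 2 by hydrogen in place of fluoro on an aromatic carbon. This is the same kind of change, not the same: in compound 1 the leaving fluoro is ortho to a fluoro group and ortho to a large group, in compound 2 it is ortho to two fluoro groups and meta to a large group. The step from compound 2 to compound 4 in this assay is expected to be a 5.2-fold higher number from compound 2 to compound 4 (0.71 log units; beyond the scatter), resting on an 11-fold higher number from compound 1 to compound 3 (1.02 log units; beyond the scatter), taken loosely because compound 2 already gives 5800 nM. For compound 4 the estimate is 30000 nM, expected between 8000 nM and 100000 nM.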

Compound 4, concentration for 50% growth inhibition: > 50000 nM
Compound 4 was reported as a limit; the forecaster's own chance of this, stated with the estimate: 25%; middle value at least 1.6-fold (0.22 log units) from the limit.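

In this assay compound 4 gives > 50000 nM, which is a limit of the assay and not a number. Hydrogen in place of fluoro on an aromatic carbon gave an at least 8.6-fold higher number from compound 2 to compound 4 (0.93 log units; beyond the scatter), so the direction of the change carries across the two cores: the same change on two cores in this assay, an 11-fold higher number (1.02 log units; beyond the scatter) from compound 1 to compound 3 and an at least 8.6-fold higher number (0.93 log units; beyond the scatter) from compound 2 to compound 4; the limit leaves it open whether they differ. From the compounds shown here alone, the exact size of the step on the core of compound 2 stays unknown, and two cores set no rule for other cores.

Going by these compounds, it remains open whether chloro or an amine in place of the leaving fluoro would give a number nearer that of fluoro or that of hydrogen on either core. Also open, on these data alone, is whether both steps would hold with a carboxylic acid in place of the methoxy group.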